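A few compounds are considered here, and "the series" means these few. Any claim that something is new, unique, unknown or untested is made for them only; others in the source may bear on it.

In an ADME assay on L1210 cells (Mus musculus) for cytotoxicity, with a stated time of 48 h (on this read-out higher numbers stand for weaker inhibition and lower numbers for stronger inhibition), compound 1 (`CC1=CCC[C@](C)(CC/C(C)=C/CC2=C(O)C(=O)C=C(N[C@@H](CO)C(=O)O)C2=O)[C@@H]1C`) reads > 10 ug/mL and that is a limit of the assay. Compound 2 (`CC1=CCC[C@](C)(CC/C(C)=C/CC2=C(O)C(=O)C=C(N[C@H](C(=O)O)[C@H](C)O)C2=O)[C@@H]1C`) likewise reads > 10 ug/mL and that too is a limit. Among the compounds with values here, compound 3 (`CC1=CCC[C@](C)(CC/C(C)=C/CC2=C(O)C(=O)C=C(N[C@H](C(=O)O)C(C)C)C2=O)[C@@H]1C`) reads 3.4 ug/mL and holds the only actual number. Compound 4 (`CC1=CCC[C@](C)(CC/C(C)=C/CC2=C(O)C(=O)C=C(NCC(=O)O)C2=O)[C@@H]1C`) differs from compound 3 by a single change (hydrogen in place of isopropyl on a saturated chain carbon bound to an amine nitrogen and a carbonyl carbon), hydrogen in place of isopropyl. Within the data shown here, two measured steps bear on this, an at least 2.9-fold lower number from compound 1 to compound 3 (0.46 log units; beyond the scatter) and an at least 2.9-fold lower number from compound 2 to compound 3 (0.46 log units; beyond the scatter), each at least modest and beyond the scatter. Both end on the isopropyl group, and neither starts from hydrogen, so they guide the direction more than the size. In this assay a modest move to a higher number is expected, and the estimated step is a 2.4-fold higher number from compound 3 to compound 4 (0.37 log units; beyond the scatter). For compound 4 the estimate is 8 ug/mL (expected range 3 ug/mL to 20 ug/mL).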

Compound 4, half-maximal inhibitory concentration: 3.5 ug/mL
For compound 4 the middle estimate is 2.3-fold (0.36 log units) above the measured one; low and high end bracket the measured number.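

In this assay, hydrogen in place of isopropyl on this saturated chain carbon leaves no readable difference (a 1.0-fold higher number from compound 3 to compound 4 (0.01 log units; within the scatter)), so the isopropyl group is not needed for the read-out here. Hydrogen also reads lower than either hydroxymethyl (an at least 2.8-fold lower number from compound 1 to compound 4 (0.45 log units; beyond the scatter)) or 1-hydroxyethyl (an at least 2.8-fold lower number from compound 2 to compound 4 (0.45 log units; beyond the scatter)), so the weaker read-outs go with those two groups alone. Both steps give only a bound, because each starts from a limit: the limit of > 10 ug/mL in this assay, at which 2 of the 4 values shown sit.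

Going by these compounds, how far the hydroxymethyl and 1-hydroxyethyl compounds actually lie from compound 4 stays open. So does the effect of an amine, a second carboxylic acid or a longer chain at this carbon.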